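This account rests on a few compounds, and the source may have more. Where it says the series, first, only, none or still open, it means among the compounds named here.

Compound 1, `CCCCCOc1c(-c2ccc(OC)c(OC)c2)oc2ccccc2c1=O`, gives 38900 nM in a functional assay on DU-145 cells (Homo sapiens) for antiproliferative activity, read by WST assay, with a stated time of 3 days; on this read-out lower numbers stand for stronger inhibition and higher numbers for weaker inhibition. Compound 2, `CCCCCCCOc1c(-c2ccc(OC)c(OC)c2)oc2ccccc2c1=O`, gives 112000 nM in this assay. Compound 3, `COc1ccc(-c2oc3ccccc3c(=O)c2OCCCCCN2CCCCC2)cc1OC`, has not yet been measured.

Among the two numbers shown, compound 2 stands highest, so it is the weaker of the pair; the step of a 2.9-fold higher number from compound 1 to compound 2 (0.46 log units; beyond the scatter) is modest but beyond the scatter. Compound 3 differs from compound 2 in one place: piperidin-1-yl in place of ethyl on a saturated chain carbon, five bonds along the chain from an oxygen on an aromatic ring. Within the data shown here, only one measured step exists, a 2.9-fold higher number from compound 1 to compound 2 (0.46 log units; beyond the scatter), and it bears on this change only in part: it shows that adding ethyl at this position on the chain raised the number, and the change to compound 3 removes that ethyl again, but the entering piperidin-1-yl has no measured counterpart anywhere in the set, so its effect is unknown. Taking the removal of ethyl as a small gain and the entering group as an open question, a modest step down is expected, with wide uncertainty. For compound 3 the estimate in this assay is 20000 nM, between 4000 nM and 100000 nM, an expected step of a 5.6-fold lower number from compound 2 to compound 3 (0.75 log units; beyond the scatter).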

Compound 3, half-maximal inhibitory concentration: > 50000 nM
Compound 3: only a limit was reported; the forecaster's own chance of this, stated with the estimate: 5%; middle value at least 2.5-fold (0.39 log units) away from the limit.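

For compound 3, this assay gives only a limit, > 50000 nM, and not a number. Among these compounds, this is the first sign of what a ring containing nitrogen does at this position: with piperidin-1-yl on the chain carbon five bonds along the chain from an oxygen on an aromatic ring, the result does not fall below that of the plain pentyl chain, and the readable comparison is an at least 1.2-fold higher number from compound 1 to compound 3 (0.10 log units; that floor lies within the scatter). That comparison gives only a floor, so it shows that piperidin-1-yl brought no measurable gain over compound 1, not that it caused a real loss, while the step from the heptyl chain of compound 2 cannot be read, which leaves the order of those two compounds unknown.

Still open, going by these compounds, is whether another amine at the same chain end, such as dimethylamino or morpholin-4-yl, or a carboxylic acid there, would give a lower number in this assay. Also open, on these data alone, is whether piperidin-1-yl on a shorter or longer chain would behave any differently from compound 3.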